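Thiazole substituent series: ethoxy to methylsulfanyl

The source may report more compounds than this note shows. Statements on the series, on what has been measured and on what is new or still open speak of the compounds shown alone.

Within the data shown here, compound 3 `CCOc1nc(C)c(-c2ccnc(Nc3ccc(OC)cc3OC)n2)s1` sits second highest of the three numbers so far in a functional assay on MV4-11 cells (Homo sapiens) for inhibition, read by resazurin assay, with a stated time of 72 h (a lower number here means a stronger inhibitor of growth, a higher number a weaker inhibitor of growth), where compound 3 gives 3890 nM. Compound 1 `CNc1nc(C)c(-c2ccnc(Nc3ccc(OC)cc3OC)n2)s1` gives 300 nM, and compound 2 `COc1ccc(Nc2nccc(-c3sc(OC(C)C)nc3C)n2)c(OC)c1` gives 8690 nM. The two alkoxy groups both fall well short of methylamino: a 29-fold higher number from compound 1 to compound 2 (1.46 log units; beyond the scatter) and a 13-fold higher number from compound 1 to compound 3 (1.11 log units; beyond the scatter), and between the two alkoxy compounds a 2.2-fold lower number from compound 2 to compound 3 (0.35 log units; beyond the scatter). Compound 4 `COc1ccc(Nc2nccc(-c3sc(SC)nc3C)n2)c(OC)c1` differs from compound 3 by methylsulfanyl in place of ethoxy on an aromatic carbon. Among the measured compounds shown here, none of the measured steps exchanges oxygen for sulfur at this position, so the only guidance is that substituents other than methylamino here have given the higher numbers, and that a smaller alkoxy group gave a somewhat lower number than a larger one. Methylsulfanyl is expected to fall in the same region as the alkoxy compounds rather than recovering the number of compound 1, so the estimated step is a 1.3-fold higher number from compound 3 to compound 4 (0.11 log units; within the scatter), with compound 4 expected at 5000 nM within 1500 nM to 16000 nM.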

Compound 4, concentration for 50% growth inhibition: 530 nM
The estimate for compound 4 lay 9.4-fold (0.97 log units) above the measured number, outside the stated range (below it).
By their numbers in this assay, from the lowest: compounds 1 and 4 (each within the scatter of the next); then compound 3; then compound 2.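

In this assay, methylsulfanyl in place of ethoxy gives a 7.3-fold lower number from compound 3 to compound 4 (0.87 log units; beyond the scatter) and methylsulfanyl in place of isopropoxy gives a 16-fold lower number from compound 2 to compound 4 (1.21 log units; beyond the scatter), so this position does not treat all groups without methylamino alike, and ethoxy and methylsulfanyl differ here despite having the same counts of hydrogen-bond donors and acceptors. Methylsulfanyl in place of methylamino gives a 1.8-fold higher number from compound 1 to compound 4 (0.25 log units; within the scatter), which places the two groups level and means methylamino is no longer the only group shown with a low number at this position. Nothing available explains the gap between the sulfur-linked and oxygen-linked groups.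

Methylsulfanyl is the only sulfur-linked group shown, so whether ethylsulfanyl would keep this low number remains open. From the compounds shown here alone, how a dimethylamino group would compare with methylamino and methylsulfanyl is also open.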